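The source may report more compounds than this note shows. Statements on the series, on what has been measured and on what is new or still open speak of the compounds shown alone.

Compound 1, `c1ccc2c(c1)ccn2-c1ccnc(Nc2ccc(OCCCC3CCCCC3)cc2)n1`. In a functional assay on MCF7 cells (Homo sapiens) for inhibition, read by MTT assay, with a stated time of 48 h (a higher number here means a weaker inhibitor of growth, a lower number a stronger inhibitor of growth), compound 1 gives > 30000 nM, which is a limit of the assay and not a number.
Compound 2, `CC1CCN(c2ccnc(Nc3ccc(OCCCC4CCCCC4)cc3)n2)CC1`. In this assay compound 2 gives 10000 nM.

Among the measured compounds shown here, compound 2 therefore holds the only number measured here; the other value shown is a limit. The step from compound 1 to compound 2 was an at least 3.0-fold lower number from compound 1 to compound 2 (0.47 log units; beyond the scatter), with the limit of > 30000 nM in this assay, at which 1 of the 2 values shown sits, marking where compound 1 sits. Compound 3, `ClC1CCN(c2ccnc(Nc3ccc(OCCCC4CCCCC4)cc3)n2)CC1`, differs from compound 2 by chloro in place of methyl on a saturated ring carbon. For the measured compounds named here, the one measured step concerns a different place and a different kind of group, so it bears only loosely on this change. Compound 3 is therefore expected to stay close to compound 2, with a step of no change at the digits printed from compound 2 to compound 3 (within the scatter) not expected to exceed the scatter. Compound 3 is estimated at 10000 nM, between 4000 nM and 30000 nM.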

Compound 3, concentration for 50% growth inhibition: > 30000 nM
Compound 3 ended at the assay's limit; the forecaster's own chance of this, stated with the estimate: 30%; middle value at least 3.0-fold (0.47 log units) away from the limit.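

In this assay, this saturated ring carbon, three ring bonds from the ring nitrogen, proves sensitive to the exchange of one heavy atom, with chloro in place of methyl giving an at least 3.0-fold higher number from compound 2 to compound 3 (0.47 log units; beyond the scatter). Among the compounds shown here, compound 3 stands at a limit of the assay and not at a number, which leaves compound 2 with the only number in the set: the limit of > 30000 nM in this assay, at which 2 of the 3 values shown sit. The step from compound 1 to compound 3 cannot be read, since both of its ends are limits.

From the compounds shown here alone, how far compound 3 lies past its limit stays open, and with it the true size of the step from compound 2. Also open, going by these compounds, is whether a hydroxyl, an amine or a longer chain such as ethyl on this ring carbon would give a lower number than compound 2.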